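Methylamino in place of methyl on compound 1

The source may hold more compounds than are shown below. What is called first, only, known or untested is meant among the compounds shown, and "the series" means these compounds.

Of the compounds shown here, two have been measured in an ADME assay on microsomes from liver (Rattus norvegicus) for metabolic stability, using NADPH; on this read-out higher numbers stand for fast clearance and lower numbers for slow clearance. Compound 1 `Cc1nc(C(=O)NCC(C)(O)C(F)(F)F)c(N)cc1C(F)(F)F` gives 0.0738 mL/min/kg, the higher of the two numbers. Compound 2 `C[C@](O)(CNC(=O)c1nc(C(F)(F)F)c(C(F)(F)F)cc1N)C(F)(F)F` gives 0.00738 mL/min/kg, which lies below the number of compound 1 by more than the usual scatter. Among the measured compounds shown here, no step between measured compounds that differ in one place is available, so the data do not show directly what a single exchange on this core does.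

Compound 3 `CNc1nc(C(=O)NCC(C)(O)C(F)(F)F)c(N)cc1C(F)(F)F` keeps the core of compound 1 and carries methylamino in place of methyl on an aromatic carbon, next to the ring nitrogen, ortho to a trifluoromethyl group and para to an amino group (methylamino in place of methyl on an aromatic carbon). For the measured compounds named here, with no measured precedent for this exchange, the expectation stays close to compound 1 at 0.0738 mL/min/kg, with a wide margin. No step beyond the usual scatter is expected in this assay, and the estimated step is a 1.4-fold higher number from compound 1 to compound 3 (0.13 log units; within the scatter). Compound 3 is expected at 0.1 mL/min/kg, with an estimated range of 0.02 mL/min/kg to 0.4 mL/min/kg.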

Compound 3, clearance: < 0.025 mL/min/kg
Compound 3 was reported as a limit; the forecaster's own chance of this, stated with the estimate: 5%; at least 4.0-fold (0.60 log units) between middle value and limit.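

Among the compounds shown here, this is the first single exchange on the core of compound 1 that can be read in this assay, and it gives an at least 2.9-fold lower number from compound 1 to compound 3 (0.47 log units; beyond the scatter) on replacing methyl with methylamino. The aromatic carbon next to the ring nitrogen, ortho to a trifluoromethyl group and para to an amino group, is therefore a place where one exchange moves this read-out beyond the scatter, and the move runs towards slow clearance. The value of compound 3 is a limit, and the step gives only a minimum size, with its full size unknown: the limit of < 0.025 mL/min/kg in this assay, at which 1 of the 3 values shown sits.

A single exchange cannot show whether the lower number goes with the added nitrogen, the hydrogen on that nitrogen or the larger group as a whole, and a dimethylamino or methoxy group on the same carbon would help to separate these. The compounds shown also leave open whether the step carries over when the amide side chain changes, for instance to one ending in a carboxylic acid.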